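A few compounds are considered here, and "the series" means these few. Any claim that something is new, unique, unknown or untested is made for them only; others in the source may bear on it.

Three compounds have been measured in a functional assay on A549 cells (Homo sapiens) for inhibition, read by MTT assay, with a stated time of 72 h; on this read-out lower numbers stand for stronger inhibition and higher numbers for weaker inhibition:

compound 1 `Cc1nc(N(C)C(=O)NC(=O)c2c(F)cccc2F)sc1C(=O)N/N=C/c1ccccc1C(F)(F)F`: 5.43 ug/mL
compound 2 `CN(C(=O)NC(=O)c1c(F)cccc1F)c1nc(C(F)(F)F)c(C(=O)N/N=C/c2ccccc2C(F)(F)F)s1`: 17.9 ug/mL
compound 3 `CN(C(=O)NC(=O)c1c(F)cccc1F)c1nc(C(F)(F)F)c(C(=O)N/N=C/c2cccc(C(F)(F)F)c2)s1`: 27.6 ug/mL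

Compound 2 gives the second highest of these three numbers. Its nearest neighbour is compound 3, separated by a 1.5-fold higher number from compound 2 to compound 3 (0.19 log units; within the scatter), a gap within the scatter. Compound 1 lies further off, since the step of a 3.3-fold higher number from compound 1 to compound 2 (0.52 log units; beyond the scatter) is a modest one beyond the scatter.

Compound 4 `CN(C(=O)NC(=O)c1ccc(Cl)cc1Cl)c1nc(C(F)(F)F)c(C(=O)N/N=C/c2ccccc2C(F)(F)F)s1` differs from compound 2 by 2,4-dichlorophenyl in place of 2,6-difluorophenyl on a carbonyl carbon. Neither measured step touches this part of the molecule: one swaps methyl for trifluoromethyl on the shared core, the other moves trifluoromethyl around the phenyl ring joined by a double bond to nitrogen. With no guidance from them, no step beyond the scatter is expected in this assay, so compound 4 is estimated at 17.9 ug/mL, between 7 ug/mL and 45 ug/mL, an expected step of no change at the digits printed from compound 2 to compound 4 (within the scatter).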

Compound 4, half-maximal inhibitory concentration: 15.3 ug/mL
Compound 4: the middle estimate sits 1.2-fold (0.07 log units) above what was measured, within the range that was stated.
By their numbers in this assay, from the lowest: compound 1; then compounds 4, 2 and 3 (each within the scatter of the next).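

In this assay, the swap at this position, 2,4-dichlorophenyl in place of 2,6-difluorophenyl on a carbonyl carbon, gives a 1.2-fold lower number from compound 2 to compound 4 (0.07 log units; within the scatter). Going by these compounds alone, this position therefore accepts this exchange of both halogen and substitution pattern with no change beyond the scatter, something the earlier steps on the shared core and the other phenyl ring could not show. No measurement here explains this result. Going by these compounds, because both features change together, their separate contributions stay unknown, and so does the outcome with a plain phenyl, a cyclohexyl ring or a longer alkyl chain on this carbonyl carbon.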